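Methyl for methoxy on a weakly active indole azo amide

A few compounds are considered here, and "the series" means these few. Any claim that something is new, unique, unknown or untested is made for them only; others in the source may bear on it.

Measured compounds:
compound 1, `O=C(Nc1cccc(Cl)c1)c1ccc(/N=N\c2c[nH]c3ccccc23)cc1`, 267000 nM
compound 2, `COc1ccccc1NC(=O)c1ccc(/N=N\c2c[nH]c3ccccc23)cc1`, "not active" (no number reported)

In a functional assay on P388 cells (Mus musculus) for inhibition, read by MTT assay, with a stated time of 72 h (on this read-out lower numbers stand for stronger inhibition and higher numbers for weaker inhibition), compound 1 gives 267000 nM, a weak result. In this assay compound 2 gives "not active" (no number reported), so no number stands for it; it sits at the inactive end of the two, without a figure to compare. Compound 3, `Cc1ccccc1NC(=O)c1ccc(/N=N\c2c[nH]c3ccccc23)cc1`, differs from compound 2 in one place: methyl in place of methoxy on an aromatic carbon. The change is small, and the two measured compounds give little to build on: one weak value and one compound reported without activity. Because compound 2 gives "not active" (no number reported), the expectation for compound 3 is a result of the same weak kind, with a fair chance that it too returns no number. Compound 3 is estimated to give 300000 nM in this assay, with a range from 100000 nM to 1000000 nM.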

Compound 3, half-maximal inhibitory concentration: "not active" (no number reported)
The entry for compound 3 holds no number; no gap can be computed for the estimate.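

In this assay, among the compounds shown here, compound 2 and compound 3 are both reported without a number, so no step between them can be read. Whether methyl and methoxy differ at this place remains open, and nothing shown offers an explanation for either result.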